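The source may hold more compounds than are shown below. What is called first, only, known or untested is meant among the compounds shown, and "the series" means these compounds.

Measured so far in a functional assay on K562 cells (Homo sapiens) for cytotoxicity, read by MTT assay, with a stated time of 24 h; on this read-out higher numbers stand for weaker inhibition and lower numbers for stronger inhibition
compound 1 `COc1cc(/C=C2\CN(C)C/C(=C\c3ccc(F)cc3)C2=O)cc(OC)c1` (11300 nM)
compound 2 `COc1cc(/C=C2\CN(C)C/C(=C\c3ccc(Br)cc3)C2=O)cc(OC)c1` (7420 nM)

Among the compounds with values here, compound 2 stands level with the only other measured compound, and the two values lie within the scatter of each other. Compound 3 `COc1cc(/C=C2\CN(C)C/C(=C\c3ccc(Cl)cc3Cl)C2=O)cc(OC)c1` follows with 2,4-dichlorophenyl in place of 4-bromophenyl on a double-bonded chain carbon bound to a double-bonded ring carbon as its change, 2,4-dichlorophenyl in place of 4-bromophenyl on a double-bonded chain carbon bound to a double-bonded ring carbon. Within the data shown here, the one measured step that bears on this is a halogen exchange (a 1.5-fold lower number from compound 1 to compound 2 (0.18 log units; within the scatter)). Among the measured compounds shown here, no measured compound has a dichlorophenyl group. No step beyond the scatter is therefore expected in this assay (a 1.1-fold lower number from compound 2 to compound 3 (0.03 log units; within the scatter)). Compound 3 is estimated at 7000 nM (expected range 3000 nM to 16000 nM).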

Compound 3, half-maximal inhibitory concentration: 11900 nM
Beside the measured number, compound 3's estimate is 1.7-fold (0.23 log units) below it; low and high end bracket the measured number.
By their numbers in this assay, from the lowest: compounds 2, 1 and 3 (each within the scatter of the next).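

In this assay, the step to 2,4-dichlorophenyl gives a 1.6-fold higher number from compound 2 to compound 3 (0.21 log units; within the scatter) and, measured against 4-fluorophenyl, a 1.1-fold higher number from compound 1 to compound 3 (0.02 log units; within the scatter) at this place. A second halogen on the phenyl group, and not only an exchange of one halogen for another, therefore leaves the number within the scatter across these three compounds. No measurement on hand accounts for these values.

Still open, as far as these compounds go, is whether an amine or a carboxylic acid on this phenyl group would give a step beyond the scatter. Also open, from the compounds shown here alone, is the effect of a change to the methyl group on the ring nitrogen.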